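Iodo for isopropyl next in a sulfonate ester series

A few compounds are considered here, and "the series" means these few. Any claim that something is new, unique, unknown or untested is made for them only; others in the source may bear on it.

Measured so far:
compound 1, `CC(=O)Nc1ccc(S(=O)(=O)Oc2ccccc2I)cc1`, 27000 nM
compound 2, `O=C(CCCl)Nc1ccc(S(=O)(=O)Oc2ccccc2I)cc1`, 12000 nM
compound 3, `CCNC(=O)Nc1ccc(S(=O)(=O)Oc2ccccc2C(C)C)cc1`, 4700 nM

All three compounds were tested in a functional assay on M21 cells (Homo sapiens) for antiproliferative activity, read by sulforhodamine B assay, with a stated time of 48 h; a higher number here means a weaker inhibitor, a lower number a stronger inhibitor. Among the measured compounds shown here, compound 1 gives 27000 nM, and compound 2 gives 12000 nM; the one measured single-point step, a 2.3-fold lower number from compound 1 to compound 2 (0.35 log units; beyond the scatter), is modest. Compound 3 gives 4700 nM and stands lowest of the three numbers, beyond the scatter from both compound 2 and compound 1.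

The next compound, compound 4, `CCNC(=O)Nc1ccc(S(=O)(=O)Oc2ccccc2I)cc1`, keeps the ethylurea of compound 3 and changes only one place: iodo in place of isopropyl on an aromatic carbon. For the measured compounds named here, no measured step bears directly on this exchange; compound 1 and compound 2 carry the iodo but differ from compound 3 in the group on the other ring as well, so their values only show that iodo compounds with an acetamide or chloropropanamide give higher numbers than compound 3. Going by the values given here, the one measured step, a 2.3-fold lower number from compound 1 to compound 2 (0.35 log units; beyond the scatter), concerns a different position. The expectation is therefore a step of uncertain direction, likely small, in this assay. Compound 4 is estimated at 6000 nM, within 2000 nM to 18000 nM, which means an expected step of a 1.3-fold higher number from compound 3 to compound 4 (0.11 log units; within the scatter).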

Compound 4, half-maximal inhibitory concentration: 5600 nM
For compound 4 the middle estimate is 1.1-fold (0.03 log units) above the measured one, within the range that was stated.
By their numbers in this assay, from the lowest: compounds 3 and 4 (each within the scatter of the next); then compound 2; then compound 1.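

In this assay, the exchange of iodo for isopropyl on an aromatic carbon, ortho to a large group, can now be read directly: a 1.2-fold higher number from compound 3 to compound 4 (0.08 log units; within the scatter), so the two groups cannot be told apart at this place in this read-out. Among the compounds shown here, with the iodo held fixed, the group on the carbonyl carbon can also be compared for the first time: ethylamino in place of methyl gives a 4.8-fold lower number from compound 1 to compound 4 (0.68 log units; beyond the scatter), and ethylamino in place of 2-chloroethyl gives a 2.1-fold lower number from compound 2 to compound 4 (0.33 log units; beyond the scatter), so the higher numbers of compound 1 and compound 2 go with the group on the carbonyl carbon rather than with the iodo. No independent measurement is available to explain any of these steps.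

As far as these compounds go, whether plain hydrogen or a methoxy group on this aromatic carbon would give a number in the same range as iodo and isopropyl remains open, as does whether the match between those two groups would hold with methyl or 2-chloroethyl on the carbonyl carbon. How a longer chain, such as propylamino, on the carbonyl carbon would compare with ethylamino is also left open.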